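From Hydroxy to Methoxy in a Growth Inhibition Series

The compounds below may be only part of what the source reports. "The series", "measured", "known", "first", "only" and "open" are said of these compounds alone.

Of the compounds shown here, two sharing one core have been tested in a functional assay on SW-620 cells (Homo sapiens) for cytotoxicity; a lower number here means a stronger inhibitor of growth, a higher number a weaker inhibitor of growth. Compound 1 `COc1ccc(C2=C(c3cc(OC)c(OC)c(OC)c3)CC3CCCN3C2=O)cc1O` reached a limit of the assay, > 100000 nM, rather than a number. Among the measured compounds shown here, compound 2 `COc1ccc(C2=C(c3ccc(SC)cc3)CC3CCCN3C2=O)cc1O` gave 20000 nM in this assay, which makes it the only compound of the pair with an actual number.

Compound 3 `COc1ccc(C2=C(c3ccc(SC)cc3)CC3CCCN3C2=O)cc1OC` is derived from compound 2 by placing methyl in place of hydrogen on an oxygen on an aromatic ring, a change of hydroxy to methoxy (methyl in place of hydrogen on an oxygen on an aromatic ring). For the measured compounds named here, no measured pair shows this change, so any expectation for it is loose. Starting from compound 2 at 20000 nM, a small move towards weaker growth inhibition in this assay is expected, perhaps not much beyond the scatter. The estimated step of a 1.5-fold higher number from compound 2 to compound 3 (0.18 log units; within the scatter) is therefore modest. For compound 3 the estimate is 30000 nM, with an expected range of 8000 nM to 80000 nM.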

Compound 3, concentration for 50% growth inhibition: 3000 nM
The estimate for compound 3 lay 10-fold (1.00 log units) above the measured number; the whole stated range lies above it.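

In this assay the change of hydroxy to methoxy gives a 6.7-fold lower number from compound 2 to compound 3 (0.82 log units; beyond the scatter), the only step among these compounds that can be read. This shows that the hydrogen on this oxygen is not required for growth inhibition in this pair, since compound 3, which carries methyl there, is the stronger inhibitor of the two. Nothing shown here gives a cause for this step.

On these data alone, for compound 1, which also keeps the hydroxy, the result of > 100000 nM is a limit of the assay and not a number, so whether the same change acts on that compound stays open. As far as these compounds go, it also remains open whether a longer chain on this oxygen, such as ethoxy, or an amine in place of the methoxy would match, exceed or lose the effect seen in compound 3.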